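The source may hold more compounds than are shown below. What is called first, only, known or untested is meant among the compounds shown, and "the series" means these compounds.

Measured so far in an ADME assay on HepG2 cells (Homo sapiens) for cytotoxicity, read by CellTiter-Glo and resazurin assay, with a stated time of 72 h; on this read-out lower numbers stand for an effect already at smaller amounts and higher numbers for an effect only at larger amounts of compound:

compound 1 `CC(C)N(Cc1cccc(OCCCCCC(=O)O)c1)C(=O)c1ccc(-c2ccco2)cc1` gives > 26000 nM, which is a limit of the assay and not a number.
compound 2 `CCOC(=O)CCCCCOc1cccc(CN(C(=O)c2ccc(-c3ccco3)cc2)C(C)C)c1` gives > 26000 nM, again a limit of the assay.
compound 3 `CCOC(=O)CCCCCOc1cccc(CN(C(=O)c2ccc(-c3cn(S(=O)(=O)c4ccccc4)c4ccccc34)cc2)C(C)C)c1` gives > 26000 nM, again a limit of the assay.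

Compound 2 differs from compound 1 by an ethyl in place of hydrogen on an oxygen next to a carbonyl group, and the step that the two limits leave unreadable from compound 1 to compound 2 cannot be read, because both ends are limits. Compound 2 therefore stands where every compound shown stands: at the limit, with its true value unknown. This is summed up by the limit of > 26000 nM in this assay, at which 3 of the 3 values shown sit.

Compound 4 `CCOC(=O)CCCCCOc1cccc(CN(C(=O)c2ccc(-c3cccc(Cl)c3)cc2)C(C)C)c1` differs from compound 2 in one place: 3-chlorophenyl in place of furan-2-yl on an aromatic carbon. Within the data shown here, no measured step concerns this change, and the one measured step, from compound 1 to compound 2, is unreadable. Among the measured compounds shown here, the only guide is that all three measured compounds sit at the limit, so no step beyond the usual scatter is expected in this assay , in either direction. Compound 4 is therefore expected to report a limit as well, with an estimated value of 30000 nM and a range from 14000 nM to 70000 nM. The expected step that the limit leaves unreadable from compound 2 to compound 4 is accordingly estimated as essentially none.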

Compound 4, half-maximal effective concentration: > 18400 nM
Compound 4: a limit, no number (the forecaster's own chance of this, stated with the estimate: 80%); the middle value is on the limit's open side.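

In this assay compound 4 gives > 18400 nM, which is a limit of the assay and not a number. Compound 2 also sits at a limit, so the step between compound 2 and compound 4 cannot be read. The compounds shown leave open where the true value of any of them lies, and whether 3-chlorophenyl in place of furan-2-yl changes it at all.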